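From Indolyl to Ethoxyphenyl with Only Limits to Guide

The source may hold more compounds than are shown below. What is called first, only, known or untested is meant among the compounds shown, and "the series" means these compounds.

Compound 1 `CCOC(=O)CCCCCOc1cccc(CN(C(=O)c2ccc(-c3ccc4ccccc4c3)cc2)C(C)C)c1` and compound 2 `CCOC(=O)CCCCCOc1cccc(CN(C(=O)c2ccc(-c3ccc4[nH]ccc4c3)cc2)C(C)C)c1` share one core and differ at a single aromatic carbon. In an ADME assay on Raji cells (Homo sapiens) for cytotoxicity, read by CellTiter-Glo and resazurin assay, with a stated time of 72 h (a lower number here means that less compound is needed, a higher number that more compound is needed for the effect), compound 1 reaches only the limit of the assay, > 26000 nM. Compound 2 likewise reaches only the limit, > 26000 nM. The step that the two limits leave unreadable from compound 1 to compound 2 therefore has no readable size. Both measured values fall at the limit of > 26000 nM in this assay, at which 2 of the 2 values shown sit, so compound 2 stands at the limit with no number of its own.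

Compound 3 `CCOC(=O)CCCCCOc1cccc(CN(C(=O)c2ccc(-c3cccc(OCC)c3)cc2)C(C)C)c1` carries 3-ethoxyphenyl in place of 1H-indol-5-yl on an aromatic carbon. Among the compounds with values here, the only measured step, hidden by two limits, says nothing about the size or direction such a change might bring in this assay. With nothing to read, compound 3 is expected to stay near the same limit, and the estimated step of a number no higher from compound 2 to compound 3 (the limit leaves the size open) amounts to none beyond the scatter. For compound 3 the expected value in this assay is 26000 nM, with a range from 9000 nM to 80000 nM.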

Compound 3, half-maximal effective concentration: > 22300 nM
Compound 3 ended at the assay's limit (the forecaster's own chance of this, stated with the estimate: 80%); the middle value is on the limit's open side.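

In this assay compound 3 gives > 22300 nM, which is a limit and not a number. The steps among compound 1, compound 2 and compound 3 cannot be read. The compounds shown leave open how far these three lie apart, and whether any group at this place gives a measurable value.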